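The source may report more compounds than this note shows. Statements on the series, on what has been measured and on what is new or still open speak of the compounds shown alone.

Of the compounds shown here, three built on a shared core have been tested in an assay on isolated protein for inhibition of Retinaldehyde dehydrogenase 3 (Homo sapiens); on this read-out lower numbers stand for stronger inhibition and higher numbers for weaker inhibition. In this assay compound 1 `CC(Sc1nc2c(cnn2C)c(=O)n1-c1ccccc1)c1ccccn1` gives 89 nM, and compound 3 `CC(Sc1nc2nn(C3(C)COC3)cc2c(=O)n1-c1ccccc1)c1ccccc1` gives 50 nM. Compound 2 `CC(Oc1nc2c(cnn2C)c(=O)n1-c1ccccc1)c1ccccc1` gives 600 nM, the highest number of the three; its distance from compound 1 and from compound 3 lies beyond the usual scatter of repeated measurements, so compound 2 is the weakest inhibitor among those measured so far.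

Compound 4 `Cn1ncc2c(=O)n(-c3ccccc3)c(OCc3cccc(F)c3)nc21` has not yet been measured. It differs from compound 2 in a single place: 3-fluorobenzyl in place of 1-phenylethyl on an oxygen on an aromatic ring. The group that leaves and the group that enters each carry one six-membered aromatic ring of carbon only, and neither brings hydrogen-bond donors or acceptors. Among the measured compounds shown here, no two measured compounds differ in exactly one place, so there is no measured step of this kind to lean on; compound 1 and compound 3 differ from compound 2 in several places at once.

For that reason only a modest change is expected: the step from compound 2 to compound 4 is estimated at a 1.2-fold lower number from compound 2 to compound 4 (0.08 log units; within the scatter), not beyond the scatter. Compound 4 is expected to give about 500 nM in this assay, within a range from 150 nM to 2000 nM.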

Compound 4, half-maximal inhibitory concentration: 1700 nM
Compound 4: middle estimate off by 3.4-fold (0.53 log units), on the low side, within the range that was stated.
By their numbers in this assay, from the lowest: compounds 3 and 1 (each within the scatter of the next); then compound 2; then compound 4.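

The oxygen substituent on the shared core is a place where the choice of group matters: in this assay, 3-fluorobenzyl in place of 1-phenylethyl gives a 2.8-fold higher number from compound 2 to compound 4 (0.45 log units; beyond the scatter) even though both groups have the same heavy-atom count, each carries one six-membered aromatic ring of carbon only, and neither has hydrogen-bond donors or acceptors. Those shared counts therefore do not settle the inhibition at this position. Nothing measured here accounts for the direction of this step.

The swap removes the methyl branch of 1-phenylethyl and brings in fluorine at the same time, so the compounds shown cannot tell which of the two matters. Going by these compounds, a plain benzyl group on the same oxygen would separate them, and whether the same change would behave alike in the sulfur-linked compounds also stays open.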